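Trimming the Sulfonamide Chain on the Weaker Analogue

The compounds below may be only part of what the source reports. "The series", "measured", "known", "first", "only" and "open" are said of these compounds alone.

Compound 1 `CCS(=O)(=O)Nc1ccc(Oc2ccc(F)cc2)c(-c2cn(C)c(=O)c3cncn23)c1`: in a functional assay on HL-60 cells (Homo sapiens) for antiproliferative activity, read by MTT assay (on this read-out lower numbers stand for stronger inhibition and higher numbers for weaker inhibition), compound 1 gives 45 nM
Compound 2 `CCS(=O)(=O)Nc1ccc(Oc2ccc(-c3c(C)noc3C)cc2)c(-c2cn(C)c(=O)c3cncn23)c1`: in this assay compound 2 gives 510 nM

Among the measured compounds shown here, only two compounds have been measured so far. Compound 2 holds the higher of the two numbers, that is, the weaker inhibition of cell growth. For the measured compounds named here, its nearest neighbour is compound 1, and the single measured step between them, an 11-fold higher number from compound 1 to compound 2 (1.05 log units; beyond the scatter), swapped the fluoro on an aromatic carbon for the 3,5-dimethyl-1,2-oxazol-4-yl group and moved the number well beyond the scatter.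

Compound 3 `Cc1noc(C)c1-c1ccc(Oc2ccc(NS(C)(=O)=O)cc2-c2cn(C)c(=O)c3cncn23)cc1` is the next analogue. It differs from compound 2 in one place: hydrogen in place of methyl on a saturated chain carbon bound to a sulfonyl sulfur. In other words the ethylsulfonyl becomes a methylsulfonyl, and the (ethylsulfonyl)amino becomes methanesulfonamido.

Going by the values given here, no measured step touches this sulfonamide chain; the one step known, an 11-fold higher number from compound 1 to compound 2 (1.05 log units; beyond the scatter), lies at the opposite end of the molecule and says nothing about shortening the chain by a single carbon. Such a small trimming, with no ring, donor or acceptor lost, is expected to give no step beyond the scatter. The estimate for compound 3 in this assay is therefore 500 nM, with a range from 150 nM to 1700 nM, an expected step of a 1.0-fold lower number from compound 2 to compound 3 (0.01 log units; within the scatter).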

Compound 3, half-maximal inhibitory concentration: 1120 nM
Compound 3: middle estimate off by 2.2-fold (0.35 log units), on the low side; the range from low to high includes it.
By their numbers in this assay, from the lowest: compound 1; then compound 2; then compound 3.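

The sulfonamide chain turns out to be a place where a small edit registers: in this assay, going from ethylsulfonyl to methylsulfonyl gives a 2.2-fold higher number from compound 2 to compound 3 (0.34 log units; beyond the scatter), a modest step, but one that lies beyond the usual scatter. Among the compounds shown here, this is the first measured change at this end of the molecule, and it shows that the read-out responds to the loss of a single carbon, even though no ring, hydrogen-bond donor or hydrogen-bond acceptor changes. Of this pair, the ethyl compound holds the lower number, so on this scaffold with the 3,5-dimethyl-1,2-oxazol-4-yl group, the longer of the two chains goes with stronger inhibition of cell growth. No accompanying data offer an explanation for this shift.

Still open, as far as these compounds go, is whether the trend continues with a longer chain, such as propyl, or reverses with a branched one, such as isopropyl, on the same sulfonyl group. From the compounds shown here alone, it is also open whether the same trimming would give a step of similar size on compound 1, where fluoro takes the place of the 3,5-dimethyl-1,2-oxazol-4-yl group.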